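This account rests on a few compounds, and the source may have more. Where it says the series, first, only, none or still open, it means among the compounds named here.

Working notes on the series. Compound 1 `CCOC(=O)c1c(C)coc1-c1ccc2c(CC)cccc2c1OC` in a functional assay on DU-145 cells (Homo sapiens) for cytotoxicity, read by MTT assay, with a stated time of 72 h (a lower number here means that less compound is needed, a higher number that more compound is needed for the effect), gives 2.2 ug/mL. Compound 2 `CCCOC(=O)c1c(C)coc1-c1ccc2c(CC)cccc2c1OC` returns only a limit of the assay, > 10 ug/mL. Compound 3 `CCOCc1c(C)coc1-c1ccc2c(CC)cccc2c1OC` likewise returns only a limit of the assay, > 10 ug/mL. On the numbers shown, compound 3 therefore stands at the top edge of the set, with nothing above it to place it against; this is reflected in the limit of > 10 ug/mL in this assay, at which 2 of the 3 values shown sit.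

The measured steps are an at least 4.5-fold higher number from compound 1 to compound 2 (0.65 log units; beyond the scatter) and an at least 4.5-fold higher number from compound 1 to compound 3 (0.65 log units; beyond the scatter), both beyond the scatter and both running toward the limit. The step that the two limits leave unreadable from compound 2 to compound 3 is not readable, as both ends are limits.

Compound 4 `CCc1cccc2c(OC)c(-c3occ(C)c3COC(=O)CCN(CC)CC)ccc12` differs from compound 3 by (2-(diethylamino)ethyl)carbonyl in place of ethyl on an oxygen on a saturated carbon. Among the measured compounds shown here, no measured step alters the group on this oxygen, so none bears directly on it. For the measured compounds named here, the only step touching this part of the molecule, an at least 4.5-fold higher number from compound 1 to compound 3 (0.65 log units; beyond the scatter), shows that an ester at this position can sit well inside the measured range while the ether sits at the limit. In this assay compound 4 is therefore estimated at 8 ug/mL, in the range 2 ug/mL to 30 ug/mL. From the limit of compound 3, the expected step is an at least 1.2-fold lower number from compound 3 to compound 4 (0.09 log units; that floor lies within the scatter), with substantial uncertainty.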

Compound 4, concentration for half-maximal effect: > 10 ug/mL
Compound 4 was reported as a limit (the forecaster's own chance of this, stated with the estimate: 45%); at least 1.2-fold (0.09 log units) between middle value and limit.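

Compound 4 returns only a limit of the assay in this assay, > 10 ug/mL. Compound 3 also stands at a limit, so no new step can be read between compound 3 and compound 4. The compounds shown leave open how compound 2, compound 3 and compound 4 rank against one another, with most of the set at one edge: the limit of > 10 ug/mL in this assay, at which 3 of the 4 values shown sit.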